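A few compounds are considered here, and "the series" means these few. Any claim that something is new, unique, unknown or untested is made for them only; others in the source may bear on it.

Compound 1 `CCOC(=O)c1c(Cl)nc2ccccc2c1-c1ccccc1` and compound 2 `CCCNC(=O)c1c(CN(CC)Cc2ccccc2)nc2ccccc2c1-c1ccccc1` share a core and were both tested in an assay on brain with Translocator protein (Rattus norvegicus) as the target; on this read-out higher numbers stand for weaker inhibition and lower numbers for stronger inhibition. In this assay compound 1 gives 3700 nM, and compound 2 gives 872 nM. Compound 2 thus stands at the lower of the two numbers, and its separation from compound 1 lies beyond the usual scatter of repeated measurements. Compound 3 `CCN(Cc1ccccc1)Cc1nc2ccccc2c(-c2ccccc2)c1C(=O)N(C)c1ccc(Cl)cc1` has not yet been measured in this assay. It departs from compound 2 by a single change: (4-chlorophenyl)(methyl)amino in place of propylamino on a carbonyl carbon. No measured pair shows this change directly, so nothing is known from the shown compounds about its effect. The expectation is nonetheless that compound 3 will give a lower number than compound 2, a step estimated as a 4.4-fold lower number from compound 2 to compound 3 (0.64 log units; beyond the scatter). On that basis the value of compound 3 in this assay is estimated at 200 nM, with a range from 30 nM to 1500 nM.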

Compound 3, half-maximal inhibitory concentration: 2480 nM
Compound 3: middle estimate off by 12-fold (1.09 log units), on the low side; measured number above the stated range.
By their numbers in this assay, from the lowest: compound 2; then compounds 3 and 1 (each within the scatter of the next).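

In this assay, (4-chlorophenyl)(methyl)amino in place of propylamino on a carbonyl carbon gives a 2.8-fold higher number from compound 2 to compound 3 (0.45 log units; beyond the scatter), the only direct reading of a change at this position among the compounds shown. It shows that the number responds to the group at this place, and that this swap, which adds one six-membered aromatic ring and removes the one hydrogen-bond donor of propylamino, raises the number rather than lowering it. No measurement shown explains this rise.

Among these compounds, the chlorine, the methyl and the ring all enter together, so the single step cannot show which of them matters; phenylamino, 4-chlorophenylamino or methyl(propyl)amino at this place would separate them. Also open, going by these compounds, is how a longer chain such as butylamino or a cyclic amine such as morpholine would read here.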